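Amino for chloro on the fused ring of compound 2

The compounds below may be only part of what the source reports. "The series", "measured", "known", "first", "only" and "open" are said of these compounds alone.

Among the measured compounds shown here, compound 2 `Nc1nn(C(=O)Nc2ccc(Cc3ccccc3)cc2)c2ccc(Cl)cc12` gives the lowest of the two numbers measured in a functional assay on HCT-116 cells (Homo sapiens) for antiproliferative activity, read by sulforhodamine B assay, with a stated time of 48 h (on this read-out lower numbers stand for stronger inhibition of growth and higher numbers for weaker inhibition of growth), at 467 nM; compound 1 `Nc1nn(C(=O)Nc2ccc(Cc3ccccc3)cc2)c2ccccc12` gives 7030 nM, and a 15-fold lower number from compound 1 to compound 2 (1.18 log units; beyond the scatter) is the only step known. Compound 3 `Nc1ccc2c(c1)c(N)nn2C(=O)Nc1ccc(Cc2ccccc2)cc1` carries amino in place of chloro on an aromatic carbon. For the measured compounds named here, no measured step covers an amino at this carbon; the one related step shows a large shift when a chloro enters there, yet says nothing about an amino. Compound 3 is therefore expected to weaken somewhat, a 3.2-fold higher number from compound 2 to compound 3 (0.51 log units; beyond the scatter), with an estimate of 1500 nM spanning 400 nM to 6000 nM.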

Compound 3, concentration for 50% growth inhibition: 6790 nM
For compound 3 the middle estimate is 4.5-fold (0.66 log units) below the measured one; measured number outside the range, above it.
By their numbers in this assay, from the lowest: compound 2; then compounds 3 and 1 (each within the scatter of the next).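

In this assay, amino in place of chloro on this aromatic carbon gives a 15-fold higher number from compound 2 to compound 3 (1.16 log units; beyond the scatter), while amino in place of hydrogen gives a 1.0-fold lower number from compound 1 to compound 3 (0.02 log units; within the scatter). The large step seen with chloro therefore does not extend to every group at this carbon: amino cannot be told apart from hydrogen here, and of the two groups tried in place of hydrogen, only chloro moves the number beyond the scatter. Nothing at hand explains this difference between chloro and amino.

Still open, on these data alone, is how fluoro, bromo, methyl, methoxy or nitrile at this carbon would compare with chloro. Also open, as far as these compounds go, is whether the chloro step would persist with a different group on the urea nitrogen.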